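A few compounds are considered here, and "the series" means these few. Any claim that something is new, unique, unknown or untested is made for them only; others in the source may bear on it.

Three compounds of the series share one core and differ only at a single aromatic carbon. Compound 1 `CCc1nn(CCCN2CCN(c3ccc(C)cc3)CC2)c(=O)c(N)c1C(C)=O` gives 10% in a functional assay on the whole organism (Abdomen, strain Swiss) for inhibition, with Mus musculus as the target, with stated times of 30 min, 10 min and 5 min, at a dose of 10 mg/kg by the oral route; a lower number here means a weaker effect, a higher number a stronger effect of the compound at the dose given. Compound 2 `CCCCC(=O)c1c(C)nn(CCCN2CCN(c3ccc(C)cc3)CC2)c(=O)c1N` gives 8% in this assay, the second highest of the three numbers; its nearest neighbour is compound 1, and the furthest is compound 3 `C=Cc1c(CC)nn(CCCN2CCN(c3ccc(C)cc3)CC2)c(=O)c1N`, which gives 0%. Both gaps lie within the scatter, so no order among the three can be read from them. For the measured compounds named here, the one measured step that bears on the change at hand is a number 10 percentage points lower from compound 1 to compound 3 (within the scatter), a replacement at the same aromatic carbon. Compound 4 `CCc1c(C)nn(CCCN2CCN(c3ccc(C)cc3)CC2)c(=O)c1N` has not been measured; relative to compound 2 the change is ethyl in place of butylcarbonyl on an aromatic carbon. Because a number 10 percentage points lower from compound 1 to compound 3 (within the scatter) stayed within the scatter, no step beyond the scatter is expected here either, and all three measured values sit low. The expected step is a number 3 percentage points lower from compound 2 to compound 4 (within the scatter). For compound 4 the estimate in this assay is 5%, with a range from 0% to 15%.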

Compound 4, a percentage reported as inhibition, in the whole organism at one dose (the size of the read-out at that dose, not a potency): 23%
Compound 4: middle estimate off by 18 percentage points, on the low side; the whole stated range lies below it.
By their numbers in this assay, from the lowest: compounds 3, 2 and 1 (each within the scatter of the next); then compound 4.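

At this aromatic carbon, opposite the ring nitrogen, ethyl in place of butylcarbonyl gives a number 15 percentage points higher from compound 2 to compound 4 (beyond the scatter) in this assay, so the position can move this read-out by more than the scatter. The earlier replacement at the same kind of carbon, vinyl in place of acetyl, gave only a number 10 percentage points lower from compound 1 to compound 3 (within the scatter) and so showed no such effect. No measurement on these compounds accounts for the new step.

The change removes the carbonyl and shortens the chain together, so the compounds shown do not separate the two; a butyl chain at this carbon would tell them apart. As far as these compounds go, how a hydrogen or an amine at this carbon would read in this assay also remains open.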